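The compounds below may be only part of what the source reports. "The series", "measured", "known", "first", "only" and "open" are said of these compounds alone.

Measured so far:
- compound 1, `O=[N+]([O-])c1c[nH]c(-c2nnc(Cc3ccc(F)c4ccccc34)o2)c1`; in an ADME assay on Vero cells (Chlorocebus sabaeus) for cytotoxicity, read by MTT assay, with a stated time of 72 h (on this read-out lower numbers stand for stronger inhibition and higher numbers for weaker inhibition), compound 1 gives 229000 nM
- compound 2, `Cn1cc([N+](=O)[O-])cc1-c1nnc(Cc2ccc(F)c3ccccc23)o1`; in this assay compound 2 gives 119000 nM
- compound 3, `Cc1ccc(-c2nnc(-c3cc([N+](=O)[O-])cn3C)o2)s1`; in this assay compound 3 gives 98300 nM

Compound 4, `Cc1ccc(-c2nnc(-c3cc([N+](=O)[O-])c[nH]3)o2)s1`, has not yet been measured in this assay. It derives from compound 3 by a single change, (hydrogen in place of methyl on an aromatic nitrogen). The same change has already been made once in the series, from compound 2 to compound 1, where the difference is hydrogen in place of methyl on an aromatic nitrogen; the surroundings of the changed position read the same in both cases, so this is the same change rather than merely one of the same kind. Its size there was a 1.9-fold higher number from compound 2 to compound 1 (0.28 log units; within the scatter). The difference between the core of compound 2 and the core of compound 3 is not broken down here.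

As to where compound 3 stands in this assay, the gap to compound 2 lies within the scatter and says nothing about order, while the gap to compound 1 lies beyond it, compound 3 giving the lower number of the two.

Among the compounds with values here, because the one earlier instance of this change gave a 1.9-fold higher number from compound 2 to compound 1 (0.28 log units; within the scatter), compound 4 is expected to move by about a 1.9-fold higher number from compound 3 to compound 4 (0.27 log units; within the scatter), a step that would itself stay within the scatter. Compound 4 is accordingly estimated at 185000 nM in this assay. Within the data shown here, the likely range for compound 4 is taken as 90000 nM to 400000 nM and is kept wide because it rests on the single earlier instance a 1.9-fold higher number from compound 2 to compound 1 (0.28 log units; within the scatter).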

Compound 4, half-maximal inhibitory concentration: 329000 nM
Compound 4: the middle estimate sits 1.8-fold (0.25 log units) below what was measured; measured number inside the range.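

In this assay, hydrogen in place of methyl on an aromatic nitrogen gives a 3.3-fold higher number from compound 3 to compound 4 (0.52 log units; beyond the scatter) on the core of compound 3, a step in the same direction as the one seen earlier on the core of compound 2. Although only the newer step lies beyond the scatter, the sizes of the two steps cannot be told apart: the same change on two cores in this assay, a 1.9-fold higher number (0.28 log units; within the scatter) from compound 2 to compound 1 and a 3.3-fold higher number (0.52 log units; beyond the scatter) from compound 3 to compound 4, 1.7-fold (0.24 log units) apart, within the scatter of two such steps. The change therefore carries across these two cores in direction and, within the scatter, in size, but two instances do not show that the same step would hold on any further core, and they do not show that either core alters its size.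

The compounds shown have only methyl or hydrogen on this aromatic nitrogen, so it remains open how a longer chain such as propyl, or a chain ending in an amine or a carboxylic acid, would read in this assay. As far as these compounds go, it also remains open whether the step from methyl to hydrogen would keep its direction and size on a core carrying a nitrile in place of the nitro group.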